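Chloro on the pendant phenyl: a step in the series

A few compounds are considered here, and "the series" means these few. Any claim that something is new, unique, unknown or untested is made for them only; others in the source may bear on it.

Compound 3 `Cc1ccc(Nc2nc(SCc3cn(Cc4ccccc4Cl)nn3)nc(-c3ccccc3)c2C#N)cc1` gives 3390 nM in a functional assay on B16-F10 cells (Mus musculus) for inhibition, read by MTT assay, with a stated time of 72 h (a higher number here means a weaker inhibitor, a lower number a stronger inhibitor), and stands lowest of the three numbers shown. Compound 1 `COc1ccc(Nc2nc(SCc3cn(Cc4ccccc4Cl)nn3)nc(-c3ccccc3)c2C#N)cc1` gives 3990 nM and compound 2 `N#Cc1c(Nc2ccccc2F)nc(SCc2cn(Cc3ccccc3Cl)nn2)nc1-c1ccccc1` gives 5230 nM; the steps of a 1.2-fold lower number from compound 1 to compound 3 (0.07 log units; within the scatter) and a 1.5-fold lower number from compound 2 to compound 3 (0.19 log units; within the scatter) both stay within the scatter, so compound 3 cannot be called the strongest. Compound 4 `Cc1ccc(Nc2nc(SCc3cn(Cc4ccccc4Cl)nn3)nc(-c3ccc(Cl)cc3)c2C#N)cc1` carries chloro in place of hydrogen on an aromatic carbon. Among the measured compounds shown here, every measured step in this set alters the group on the aromatic nitrogen instead, and none touches the phenyl on the shared core, so no measured step bears on this change directly. With nothing pointing either way, a step of a 1.0-fold higher number from compound 3 to compound 4 (0.00 log units; within the scatter) is expected, none beyond the scatter. Compound 4 is therefore estimated at 3400 nM in this assay, with a range from 1500 nM to 8000 nM.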

Compound 4, half-maximal inhibitory concentration: 4810 nM
The estimate for compound 4 lay 1.4-fold (0.15 log units) below the measured number; low and high end bracket the measured number.
By their numbers in this assay, from the lowest: compounds 3, 1, 4 and 2 (each within the scatter of the next).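

The step of a 1.4-fold higher number from compound 3 to compound 4 (0.15 log units; within the scatter) in this assay is the only one here made on the phenyl of the shared core rather than on the group on the aromatic nitrogen. For this pair, phenyl to 4-chlorophenyl therefore leaves the number within the scatter, so this position tolerates chloro at least in the presence of 4-methylphenyl on the nitrogen. No supporting data bear on why this is so.

Still open, going by these compounds, is whether an amine or a carboxylic acid at this same place would shift the number beyond the scatter. Also open, on these data alone, is whether chloro gives the same result with 4-methoxyphenyl or 2-fluorophenyl on the nitrogen.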